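This account rests on a few compounds, and the source may have more. Where it says the series, first, only, none or still open, it means among the compounds named here.

Three compounds of the series carry numbers in a functional assay on Urethra with Alpha-1A adrenergic receptor (Oryctolagus cuniculus) as the target; on this read-out lower numbers stand for smaller maximal responses and higher numbers for larger maximal responses. Compound 1 `CS(=O)(=O)Nc1ccc(Cl)c2c1CCCC2c1c[nH]cn1` gives 41% and stands lowest of the three. Compound 2 `CCS(=O)(=O)Nc1cccc(Cc2c[nH]cn2)c1C` gives 69%, a number beyond the scatter above compound 1, and compound 3 `CS(=O)(=O)Nc1cccc2c1OCCC2c1c[nH]cn1` gives 88%, the furthest from compound 1 and likewise beyond the scatter. No two of these three differ in a single place, so no one-step comparison is available among the measured compounds.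

Compound 4 `COc1ccc(NS(C)(=O)=O)c2c1C(c1c[nH]cn1)CCC2` awaits measurement. It differs from compound 1 in one place: methoxy in place of chloro on an aromatic carbon. Among the measured compounds shown here, no measured pair shows what this exchange does to the maximal response. Given that compound 1 sits at 41%, a moderate rise is expected, about a number 14 percentage points higher from compound 1 to compound 4 (beyond the scatter) in this assay. Compound 4 is estimated at 55%, within 30% to 80%.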

Compound 4, largest response reached (reported as efficacy), in percent of the reference or control that the assay uses: 57%
Estimate against measurement, compound 4: 2 percentage points below; low and high end bracket the measured number.
By their numbers in this assay, from the lowest: compound 1; then compound 4; then compound 2; then compound 3.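

On the core of compound 1, the aromatic carbon para to a methanesulfonamido group is sensitive to its substituent: in this assay, methoxy in place of chloro gives a number 16 percentage points higher from compound 1 to compound 4 (beyond the scatter). Among the compounds shown here, this is the only one-place comparison, so it is the first effect on the maximal response that can be assigned to a single group. No available data explain the shift. Still open, on these data alone, is whether a hydroxy group, an amine or a longer alkoxy chain such as ethoxy at this carbon would move the response further. As far as these compounds go, whether methoxy in place of chloro acts the same way on other cores also remains open.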